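Amide swap at a limit: isobutylamino to dimethylamino

This account rests on a few compounds, and the source may have more. Where it says the series, first, only, none or still open, it means among the compounds named here.

Compound 1 `C[C@H](NC(=O)[C@@]1(Cc2ccccc2)CCN1C(=O)OCc1ccccc1)C(=O)N(C)C`: in an ADME assay on HELF cells (Homo sapiens) for cytotoxicity, with a stated time of 3 days (a lower number here means that less compound is tolerated, a higher number that more compound is tolerated), compound 1 gives > 100000 nM, which is a limit of the assay rather than a number.
Compound 2 `CC(C)CNC(=O)[C@H](C)NC(=O)[C@]1(Cc2ccccc2)CCN1C(=O)OCc1ccccc1`: in this assay compound 2 gives > 100000 nM, again a limit of the assay.
Compound 3 `C[C@H](NC(=O)[C@@]1(Cc2ccccc2)CCN1C(=O)OCc1ccccc1)C(=O)NC1CCCCC1`: in this assay compound 3 gives 46000 nM.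

Compound 2 thus stands only at a limit, and it shares that position with compound 1 (the limit of > 100000 nM in this assay, at which 2 of the 3 values shown sit). Compound 4 `C[C@H](NC(=O)[C@]1(Cc2ccccc2)CCN1C(=O)OCc1ccccc1)C(=O)N(C)C` is the unmeasured partner of compound 2; the change between the two is dimethylamino in place of isobutylamino on a carbonyl carbon. Within the data shown here, only one measured step touches the same carbonyl carbon: an at least 2.1-fold lower number from compound 1 to compound 3 (0.33 log units; beyond the scatter), where cyclohexylamino in place of dimethylamino brought the number down. The move from compound 2 to compound 4 runs the other way, toward the dimethylamino group that compound 1 carries, and compound 1 sits at the limit. No step beyond the scatter is therefore expected in this assay, and the value of compound 4 is expected to sit at or near the limit once more. The expected step is a step that the limit leaves unreadable from compound 2 to compound 4. Compound 4 is estimated at 150000 nM, within 60000 nM to 400000 nM.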

Compound 4, half-maximal cytotoxic concentration: > 100000 nM
Compound 4 ended at the assay's limit; the forecaster's own chance of this, stated with the estimate: 70%; the middle value does not contradict the limit.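

In this assay compound 4 gives > 100000 nM, a limit of the assay, so no step can be read from compound 2 to compound 4 or from compound 1 to compound 4: the limit of > 100000 nM in this assay, at which 3 of the 4 values shown sit.

Still open is whether the configuration at the saturated ring carbon, or dimethylamino in place of isobutylamino, changes cytotoxicity beyond that limit: the fact that compounds 1 and 4 differ only in the configuration as drawn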